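Cyclohexyl in Place of Benzyl: Estimating Compound 4

A few compounds are considered here, and "the series" means these few. Any claim that something is new, unique, unknown or untested is made for them only; others in the source may bear on it.

In an ADME assay on HepG2 cells (Homo sapiens) for cytotoxicity, read by luminescence, CellTiter-Glo and ATP content, with a stated time of 72 h (on this read-out higher numbers stand for an effect only at larger amounts of compound and lower numbers for an effect already at smaller amounts), compound 2 `COc1ccc(F)cc1CNCCCNc1ccnc2cc(CCc3ccccc3)ccc12` gives 4240 nM, the second highest of three numbers. Compound 1 `COc1cccc(CNCCCNc2ccnc3cc(-c4ccc(C(F)(F)F)cc4)ccc23)c1O` gives 2210 nM, within the scatter of compound 2, whereas compound 3 `c1ccc(CCc2ccc3c(NCCCNCc4ccco4)ccnc3c2)cc1` gives 16000 nM, and the step of a 3.8-fold higher number from compound 2 to compound 3 (0.58 log units; beyond the scatter) reaches beyond the scatter. Compound 4 `COc1ccc(F)cc1CNCCCNc1ccnc2cc(CC3CCCCC3)ccc12` differs from compound 2 in one respect: cyclohexyl in place of benzyl on a saturated chain carbon bound to an aromatic carbon. For the measured compounds named here, the single measured step, a 3.8-fold higher number from compound 2 to compound 3 (0.58 log units; beyond the scatter), concerns a change on a saturated chain carbon bound to an amine nitrogen, not the saturated chain carbon bound to an aromatic carbon, so it does not bear directly on this change. Compound 4 is therefore expected to stay close to its parent, with a step of a 1.1-fold higher number from compound 2 to compound 4 (0.03 log units; within the scatter) that may not exceed the scatter. Compound 4 is estimated at 4500 nM, within a range from 1800 nM to 11000 nM.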

Compound 4, half-maximal effective concentration: 1830 nM
Compound 4: middle estimate off by 2.5-fold (0.39 log units), on the high side; the range from low to high includes it.
By their numbers in this assay, from the lowest: compounds 4, 1 and 2 (each within the scatter of the next, the first and the last beyond it); then compound 3.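

In this assay the saturated chain carbon bound to an aromatic carbon responds to change: cyclohexyl in place of benzyl gives a 2.3-fold lower number from compound 2 to compound 4 (0.36 log units; beyond the scatter) and so moves the number beyond the scatter. This is the first step shown at this place, and it runs in the opposite direction to a 3.8-fold higher number from compound 2 to compound 3 (0.58 log units; beyond the scatter) at the saturated chain carbon bound to an amine nitrogen. Nothing available accounts for the step. Still open, on these data alone, is what a longer chain or a morpholine ring would give in place of cyclohexyl, and whether this step would recur with the furan-2-yl of compound 3.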